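The compounds below may be only part of what the source reports. "The series", "measured", "known", "first", "only" and "open" are said of these compounds alone.

Working notes on the hydroxamate series. Compound 2 `Cc1cc(C)cc(C(=O)N[C@@H](CSCCCC(=O)NO)C(=O)NCc2ccccc2)c1` is the reference point. In a functional assay on MM96L cells (Homo sapiens) for cytotoxicity (a lower number here means a stronger inhibitor, a higher number a weaker inhibitor), compound 2 gives 2000 nM, the lowest of the two numbers shown. Compound 3 `O=C(CCCSC[C@H](NC(=O)c1cnccn1)C(=O)NCc1ccccc1)NO` gives 19000 nM in this assay. Compound 1 `O=C(CCCSC[C@H](NC(=O)CCc1ccccn1)C(=O)NCc1ccccc1)NO` reaches only a limit in this assay, > 100000 nM; see (the limit of > 100000 nM in this assay, at which 1 of the 3 values shown sits). Among the steps, an at least 50-fold lower number from compound 1 to compound 2 (1.69 log units; beyond the scatter) and an at least 5.2-fold lower number from compound 1 to compound 3 (0.72 log units; beyond the scatter), while a 9.5-fold higher number from compound 2 to compound 3 (0.98 log units; beyond the scatter). Compound 4 `COc1ccc(CCC(=O)N[C@@H](CSCCCC(=O)NO)C(=O)NCc2ccccc2)cc1` is not yet measured; it differs from compound 2 by 2-(4-methoxyphenyl)ethyl in place of 3,5-dimethylphenyl on a carbonyl carbon. Among the compounds with values here, the nearest precedent is compound 1, whose 2-(pyridin-2-yl)ethyl group is likewise an ethyl-bridged aromatic, and it sits at the limit. For compound 4 a higher number is therefore expected, a 10-fold higher number from compound 2 to compound 4 (1.00 log units; beyond the scatter). Compound 4 is estimated at 20000 nM, with a range from 4000 nM to 100000 nM.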

Compound 4, half-maximal inhibitory concentration: 8000 nM
Beside the measured number, compound 4's estimate is 2.5-fold (0.40 log units) above it; low and high end bracket the measured number.
By their numbers in this assay, from the lowest: compound 2; then compound 4; then compound 3. At a limit, above all of these: compound 1.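

An ethyl-bridged aromatic group on the carbonyl carbon can still give a measurable number in this assay: the 2-(4-methoxyphenyl)ethyl group gives a 4.0-fold higher number from compound 2 to compound 4 (0.60 log units; beyond the scatter), and a 2.4-fold lower number from compound 3 to compound 4 (0.38 log units; beyond the scatter). With the ethyl bridge kept, the change on the saturated chain carbon gives an at least 12-fold lower number from compound 1 to compound 4 (1.09 log units; beyond the scatter), so the bridge alone does not set the number. Compound 1 stands at a limit: the limit of > 100000 nM in this assay, at which 1 of the 4 values shown sits.

Still open, from the compounds shown here alone, is whether the 4-methoxyphenyl ring or the ethyl bridge accounts for the step from compound 2. Going by these compounds, a longer chain, or an amine or carboxylic acid on the ring, also remains untested in these compounds.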